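A few compounds are considered here, and "the series" means these few. Any claim that something is new, unique, unknown or untested is made for them only; others in the source may bear on it.

Working notes on the series, read out in an in vivo ADME assay on the whole organism for pharmacokinetics, with Rattus norvegicus as the target, at a dose of 10 mg/kg by the oral route; on this read-out higher numbers stand for higher exposure at the dose given and lower numbers for lower exposure. Compound 1 `COc1cc(CS(=O)(=O)N2CCN(c3cnn(-c4cccc(Cl)c4)c(=O)c3OCC3(C)CC3)CC2)ccc1N` gives 5750 nM and compound 2 `CC1(COc2c(N3CCN(S(=O)(=O)Cc4ccc(N)c(F)c4)CC3)cnn(-c3cc(F)cc(F)c3)c2=O)CC1` gives 550 nM, which puts compound 2 lower of the two, by a gap beyond the scatter. These two compounds differ in more than one place, so that gap does not isolate any single change. Compound 3 `Cc1cc(CS(=O)(=O)N2CCN(c3cnn(-c4cc(F)cc(F)c4)c(=O)c3OCC3(C)CC3)CC2)ccc1N` departs from compound 2 at one place only: methyl in place of fluoro on an aromatic carbon, ortho to an amino group. For the measured compounds named here, no measured pair covers this exchange, so the expectation is loose. Going by the values given here, the only higher number so far, compound 1 at 5750 nM, gives the direction weakly. A modest rise is expected, near the edge of the scatter, estimated as a 2.2-fold higher number from compound 2 to compound 3 (0.34 log units; beyond the scatter). For compound 3 the estimate is 1200 nM, with an expected range of 300 nM to 4500 nM.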

Compound 3, maximal plasma concentration: 6250 nM
Compound 3: the middle estimate sits 5.2-fold (0.72 log units) below what was measured, and the stated range ends below it.
By their numbers in this assay, from the lowest: compound 2; then compounds 1 and 3 (each within the scatter of the next).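

In this assay, for the compounds shown here, methyl in place of fluoro on the aromatic carbon ortho to an amino group gives an 11-fold higher number from compound 2 to compound 3 (1.06 log units; beyond the scatter) and is the first single-place step, a large one. This shows that exposure at the dose given is highly sensitive to this one position, even though the exchange keeps the heavy-atom count and adds no hydrogen-bond donor, acceptor, ring or net charge. No measurement at hand explains the step.

On these data alone, it remains open whether an ethyl, a hydroxyl or a nitrile in this place would give a number like that of methyl or like that of fluoro. Also open, as far as these compounds go, is whether the same exchange would give a step of this size on a compound carrying the other groups of compound 1.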